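Swapping the aryl on the piperidine nitrogen of compound 1

The compounds below may be only part of what the source reports. "The series", "measured", "known", "first", "only" and "open" are said of these compounds alone.

Compound 1, `O=C1COc2ccc(NC(=O)C3CCN(c4ccccc4Cl)CC3)cc2N1`, in a functional assay for antagonist activity at transient receptor potential cation channel subfamily V member 1 (Homo sapiens), read by FLIPR and calcium flux (on this read-out lower numbers stand for stronger inhibition and higher numbers for weaker inhibition), gives 220 nM.
Compound 2, `CC(=O)N1CCc2ccc(NC(=O)C3CCN(c4cccc(C(F)(F)F)c4)CC3)cc21`, in this assay gives 800 nM.

Compound 1 holds the lower of the two numbers; compound 2 sits a step above it that lies beyond the scatter. Compound 3, `COc1cccc(N2CCC(C(=O)Nc3ccc4c(c3)NC(=O)CO4)CC2)c1`, keeps the core of compound 1 and changes one place: 3-methoxyphenyl in place of 2-chlorophenyl on an amine nitrogen in a ring. Among the compounds with values here, no measured pair isolates this change, so the expectation rests on compound 1 alone. The step from compound 1 to compound 3 is expected to be modest and toward a weaker number, a 1.8-fold higher number from compound 1 to compound 3 (0.26 log units; within the scatter), though it may not exceed the scatter. Compound 3 is estimated at 400 nM, with a range from 120 nM to 1300 nM.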

Compound 3, half-maximal inhibitory concentration: 1420 nM
Compound 3: middle estimate off by 3.6-fold (0.55 log units), on the low side; the whole stated range lies below it.
By their numbers in this assay, from the lowest: compound 1; then compounds 2 and 3 (each within the scatter of the next).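

Exchanging 2-chlorophenyl for 3-methoxyphenyl on the ring amine nitrogen gives a 6.5-fold higher number from compound 1 to compound 3 (0.81 log units; beyond the scatter) in this assay and shows that, with the rest of compound 1 held constant, this position is sensitive to the aryl group it carries. The change alters both the substituent and where it sits on the phenyl, so the step cannot be assigned to either alone. Nothing shown explains the rise. The compounds shown leave open how 3-chlorophenyl or 2-methoxyphenyl would read on the same core, and either would help separate those two changes.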